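From Chloro to Trifluoromethyl on One Aromatic Carbon

A few compounds are considered here, and "the series" means these few. Any claim that something is new, unique, unknown or untested is made for them only; others in the source may bear on it.

Compound 2 `O=C(/C=C/c1ccc(Cl)cc1)Nc1ccc2c(c1)OCCO2` gives 320 nM in a functional assay on CHO cells for inhibition of transient receptor potential cation channel subfamily V member 1 (Homo sapiens) (a lower number here means a stronger inhibitor, a higher number a weaker inhibitor), the lowest of the two numbers recorded so far. Among the measured compounds shown here, the only other measured compound, compound 1 `Cc1ccc(/C=C/C(=O)Nc2ccc3c(c2)OCCO3)cc1`, gives 1100 nM in this assay. For the measured compounds named here, a single step connects them, a 3.4-fold lower number from compound 1 to compound 2 (0.54 log units; beyond the scatter), and it is the only measured guidance available.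

Compound 3 `O=C(/C=C/c1ccc(C(F)(F)F)cc1)Nc1ccc2c(c1)OCCO2` carries the next change: trifluoromethyl in place of chloro on an aromatic carbon. Going by the values given here, no measured step involves a trifluoromethyl, so what can be said rests on the one step above, which showed that swapping the group on this aromatic carbon moved the number by a modest amount. A further swap at the same place is therefore expected to give at most a modest shift, and possibly none beyond the scatter.

Compound 3 is estimated to give 250 nM in this assay, with a range from 80 nM to 800 nM. This estimate corresponds to a 1.3-fold lower number from compound 2 to compound 3 (0.11 log units; within the scatter), expected to lie within the scatter.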

Compound 3, half-maximal inhibitory concentration: 100 nM
Compound 3: the middle estimate sits 2.5-fold (0.40 log units) above what was measured; the measured number falls inside the stated range.
By their numbers in this assay, from the lowest: compound 3; then compound 2; then compound 1.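

In this assay, a second swap on this aromatic carbon again moved the number beyond the scatter, with a 3.2-fold lower number from compound 2 to compound 3 (0.51 log units; beyond the scatter) for trifluoromethyl in place of chloro. Among the compounds shown here, the earlier step from methyl to chloro therefore was not the only change here that mattered, and this carbon stays sensitive to which group it carries. Across the three compounds, the full change is an 11-fold lower number from compound 1 to compound 3 (1.04 log units; beyond the scatter) and is large, so the choice of group at this one place separates these compounds clearly, and trifluoromethyl gives the lowest number of the three.

As far as these compounds go, whether an amine, a carboxylic acid or a longer chain on this carbon would lower the number further remains open. No measurement shown here explains why trifluoromethyl gives a lower number than chloro or methyl.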